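Swapping the Ether Oxygen of Compound 3 for Carbon

The compounds below may be only part of what the source reports. "The series", "measured", "known", "first", "only" and "open" are said of these compounds alone.

Values in a functional assay (aorta) with Oryctolagus cuniculus as the target; on this read-out lower numbers stand for tighter binding and higher numbers for weaker binding:
- Compound 1 `Fc1ccc(C(c2ccc(F)cc2)C2CCN(CCCOc3ccc(Br)cc3)CC2)cc1`: 1.59 nM
- Compound 2 `Fc1ccc(C(c2ccc(F)cc2)C2CCN(CCCOc3cccc4ccccc34)CC2)cc1`: 5.01 nM
- Compound 3 `Fc1ccc(C(c2ccc(F)cc2)C2CCN(CCCOc3ccccc3)CC2)cc1`: 1.59 nM
- Compound 4 `Fc1ccc(C(c2ccc(F)cc2)C2CCN(CCCCc3ccccc3)CC2)cc1`: not yet measured

Level with compound 1, compound 3 gives 1.59 nM, and the gap to the remaining measured compound is a 3.2-fold lower number from compound 2 to compound 3 (0.50 log units; beyond the scatter). The next step places benzyl in place of phenoxy on a saturated chain carbon, three bonds along the chain from an amine nitrogen in a ring. Among the measured compounds shown here, no measured step alters this place. The nearest guides change only the far aromatic end: no change at the digits printed from compound 1 to compound 3 (within the scatter) and a 3.2-fold higher number from compound 1 to compound 2 (0.50 log units; beyond the scatter). In this assay, a step no larger than these is therefore expected, slightly upward and probably within the scatter: a 1.6-fold higher number from compound 3 to compound 4 (0.20 log units; within the scatter). Compound 4 is estimated at 2.5 nM, with an expected range of 0.8 nM to 8 nM.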

Compound 4, dissociation constant: 2.51 nM
Beside the measured number, compound 4's estimate is 1.0-fold (0.00 log units) below it; the measured number falls inside the stated range.
By their numbers in this assay, from the lowest: compounds 1, 3, 4 and 2 (each within the scatter of the next, the first and the last beyond it).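

In this assay, this first change at this place on the chain, with benzyl in place of phenoxy, leaves the read-out within the scatter (a 1.6-fold higher number from compound 3 to compound 4 (0.20 log units; within the scatter)). Compound 4 also stays within the scatter of the other two ends (a 1.6-fold higher number from compound 1 to compound 4 (0.20 log units; within the scatter); a 2.0-fold lower number from compound 2 to compound 4 (0.30 log units; within the scatter)), even though those two ends are themselves separated beyond it. No evidence at hand bears on this result. From the compounds shown here alone, it remains open whether a sulfur atom or an amine nitrogen at this place, or a longer chain, would read the same. Also open, going by these compounds, is whether the same swap holds with the 4-bromophenyl or naphthalen-1-yl ends.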